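Removing the second carboxy from the aspartate-type side chain

This account rests on a few compounds, and the source may have more. Where it says the series, first, only, none or still open, it means among the compounds named here.

In a functional assay on the whole organism (Tail, strain ICR) with Mus musculus as the target, in the tail flick test, with a stated time of 30 min, at a dose of 25 umol/kg by the oral route (a lower number here means a weaker effect, a higher number a stronger effect of the compound at the dose given), compound 3 `O=C(O)C[C@H](NC(=O)CN(c1nc(Cl)nc2[nH]cnc12)C1CC1)C(=O)O` gives 19.9%, the lowest of the three numbers shown. Compound 2 `CC(C)[C@H](NC(=O)CN(c1nc(Cl)nc2[nH]cnc12)C1CC1)C(=O)O` gives 31.2% in this assay, and compound 1 `C[C@H](NC(=O)CN(c1nc(Cl)nc2[nH]cnc12)C1CC1)C(=O)OCc1ccccc1` gives 41.2% in this assay; both sit beyond the scatter above compound 3.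

Compound 4 `C[C@H](NC(=O)CN(c1nc(Cl)nc2[nH]cnc12)C1CC1)C(=O)O` is not yet measured in this assay. It differs from compound 3 by hydrogen in place of carboxy on a saturated chain carbon, two bonds along the chain from an amide-type nitrogen and a carbonyl carbon. For the measured compounds named here, the one measured step that bears on this change is the one in which a carboxymethyl came in for an isopropyl: a number 11.3 percentage points lower from compound 2 to compound 3 (beyond the scatter). Compound 4 goes the other way, dropping the carboxy from the side chain, so a move back up of about that size is expected in this assay. Going by the values given here, compound 1 and compound 4 differ at the ester rather than at the side chain, and no single-place step is available for that pair; the two values only show where the alanine-type side chain has been seen so far.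

For compound 4 a rise is expected in this assay, a number 11.1 percentage points higher from compound 3 to compound 4 (beyond the scatter). The estimate for compound 4 in this assay is 31%, with a range from 19% to 43%.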

Compound 4, a percentage reported as activity, at one dose (the size of the read-out at that dose, not a potency): 48.1%
Beside the measured number, compound 4's estimate is 17.1 percentage points below it; measured number above the stated range.
By their numbers in this assay, from the lowest: compound 3; then compounds 2, 1 and 4 (each within the scatter of the next, the first and the last beyond it).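

In this assay, the saturated chain carbon turns out to be sensitive to more than the carboxy alone. Alongside a number 28.2 percentage points higher from compound 3 to compound 4 (beyond the scatter), the change of methyl in place of isopropyl gives a number 16.9 percentage points higher from compound 2 to compound 4 (beyond the scatter), with no carboxy involved in that step, so among the three free acids the side chains rank carboxymethyl, then isopropyl, then methyl, each beyond the scatter of the next. At the ester the picture is different: a number 6.9 percentage points higher from compound 1 to compound 4 (within the scatter) leaves the benzyl ester and the free carboxylic acid unseparated on the alanine-type side chain, so the earlier value of compound 1 reflects no gain that can be credited to the benzyl. Nothing measured here explains any of these steps.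

Still open, on these data alone, is whether the series continues past methyl, with a bare hydrogen, an ethyl or a longer chain on that carbon, and whether an amine at the end of the side chain behaves like the carboxy. Also open, as far as these compounds go, is whether a benzyl ester stays as neutral on the isopropyl and carboxymethyl side chains as it does on the methyl one.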